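The source may hold more compounds than are shown below. What is called first, only, known or untested is meant among the compounds shown, and "the series" means these compounds.

Measured so far, in a functional assay on NCI-H1975 cells (Homo sapiens) for inhibition, read by MTT assay, with a stated time of 72 h; on this read-out lower numbers stand for stronger inhibition and higher numbers for weaker inhibition:
- compound 1, `C=CC(=O)Nc1cccc(NC(=O)CSc2nc(Nc3ccccc3Br)c3ccccc3n2)c1`, gives 19300 nM
- compound 2, `C=CC(=O)Nc1cccc(NC(=O)CSc2nc(Nc3ccccc3C)c3ccccc3n2)c1`, gives 9920 nM
- compound 3, `C=CC(=O)Nc1cccc(NC(=O)CSc2nc(Nc3ccc(Cl)cc3)c3ccccc3n2)c1`, gives 7580 nM

Compound 3 holds the lowest number of the three, but only the gap to compound 1 is beyond the scatter, shown by a 2.5-fold lower number from compound 1 to compound 3 (0.41 log units; beyond the scatter); against compound 2 the step of a 1.3-fold lower number from compound 2 to compound 3 (0.12 log units; within the scatter) is within the scatter, so compound 2 and compound 3 cannot be ordered. The step of a 1.9-fold lower number from compound 1 to compound 2 (0.29 log units; within the scatter) is likewise within the scatter.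

Compound 4, `C=CC(=O)Nc1cccc(NC(=O)CSc2nc(Nc3cc(OC)c(OC)c(OC)c3)c3ccccc3n2)c1`, differs from compound 3 as follows: 3,4,5-trimethoxyphenyl in place of 4-chlorophenyl on a nitrogen on an aromatic ring. Going by the values given here, no measured step bears directly on a trimethoxy-substituted ring on this nitrogen; the three steps at hand all concern a single halogen or methyl and are small or within the scatter. The shared core with its acrylamide has so far kept every number in the same narrow band. For this assay a step of no more than the usual scatter is therefore expected for compound 4, direction undetermined, as a 1.0-fold lower number from compound 3 to compound 4 (0.00 log units; within the scatter). The estimate for compound 4 is 7500 nM, with a range from 2500 nM to 22000 nM.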

Compound 4, half-maximal inhibitory concentration: > 50000 nM
Compound 4 was reported as a limit; the forecaster's own chance of this, stated with the estimate: 5%; middle value at least 6.6-fold (0.82 log units) away from the limit.
By their numbers in this assay, from the lowest: compounds 3, 2 and 1 (each within the scatter of the next, the first and the last beyond it). At a limit, above all of these: compound 4.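

In this assay compound 4 gives > 50000 nM as a limit of the assay and not as a number. The group on this nitrogen can therefore move the read-out beyond the scatter, which the single halogen and methyl changes had shown only for the pair of compound 1 and compound 3; 3,4,5-trimethoxyphenyl gives an at least 6.5-fold higher number from compound 3 to compound 4 (0.81 log units; beyond the scatter) against 4-chlorophenyl, an at least 5.0-fold higher number from compound 2 to compound 4 (0.70 log units; beyond the scatter) against 2-methylphenyl and an at least 2.5-fold higher number from compound 1 to compound 4 (0.41 log units; beyond the scatter) against 2-bromophenyl. The shared core with its acrylamide thus does not by itself hold the number in the band of compound 1, compound 2 and compound 3.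

Which of the methoxy groups carries this step stays open, as does the effect of a single methoxy group on the phenyl ring. Going by these compounds, a dimethylamino group or a carboxylic acid on that ring also remains untested.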